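A few compounds are considered here, and "the series" means these few. Any claim that something is new, unique, unknown or untested is made for them only; others in the source may bear on it.

Measured compounds, all in a functional assay on aorta (Rattus norvegicus, strain Wistar) for inhibition; a lower number here means a stronger inhibitor, a higher number a weaker inhibitor:

- compound 1, `CC1(C)OC(=O)C2(C(=O)O1)C(c1cccs1)C(c1ccccc1)=NN2c1cccc(Cl)c1`, gives 321000 nM
- compound 2, `Cc1ccc(C2C(c3ccccc3)=NN(c3ccccc3)C23C(=O)OC(C)(C)OC3=O)o1`, gives 719000 nM

Compound 2 stands highest of the two numbers in this assay, so it is the weaker inhibitor of the pair; the nearest number is that of compound 1, which lies lower by a margin that is beyond the usual scatter. Among the compounds with values here, the two compounds differ in more than one place, so no single step between them can be read off.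

Compound 3, `Cc1ccc(C2C(c3ccccc3)=NN(c3cccc(Cl)c3)C23C(=O)OC(C)(C)OC3=O)o1`, is not yet measured. It differs from compound 2 in one place: chloro in place of hydrogen on an aromatic carbon. The difference sits on the phenyl attached to the ring nitrogen of the shared core, at the position given as meta to a large group. Compound 1 also carries a chloro on that phenyl, though it carries a different five-membered ring at the other position, so it cannot serve as a clean step.

Given that compound 1 gives 321000 nM, a modest move toward a lower number is expected for compound 3 in this assay, though a step within the scatter is equally plausible. The expected step is a 1.6-fold lower number from compound 2 to compound 3 (0.20 log units; within the scatter). Compound 3 is estimated at 450000 nM, within 200000 nM to 1000000 nM.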

Compound 3, half-maximal inhibitory concentration: 729000 nM
Compound 3: middle estimate off by 1.6-fold (0.21 log units), on the low side, and the stated range covers the measured number.
By their numbers in this assay, from the lowest: compound 1; then compounds 2 and 3 (each within the scatter of the next).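

Working notes on the series. In this assay the exchange of phenyl for 3-chlorophenyl, with chloro in place of hydrogen at the place meta to a large group, gives a 1.0-fold higher number from compound 2 to compound 3 (0.01 log units; within the scatter) and so leaves compound 2 and compound 3 indistinguishable while 5-methylfuran-2-yl stays on the saturated ring carbon. With 3-chlorophenyl held fixed, the change on the saturated ring carbon gives a 2.3-fold higher number from compound 1 to compound 3 (0.36 log units; beyond the scatter) as a modest step, which makes 5-methylfuran-2-yl in place of thiophen-2-yl the only single change shown here that can be read beyond the scatter. No measurement at hand explains either step.

Open is whether chloro in place of hydrogen would also leave the number within the scatter with thiophen-2-yl on the saturated ring carbon, since the one chloro step shown carries 5-methylfuran-2-yl. Also open, as far as these compounds go, is how an amine, a methoxy group or a carboxylic acid at the same place on the phenyl would read in this assay when set against chloro and hydrogen.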